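Half-life of compound 3 and its methoxy counterpart

This account rests on a few compounds, and the source may have more. Where it says the series, first, only, none or still open, it means among the compounds named here.

Compound 1 `COCc1cc(CCCOc2c(C)cc(-c3noc(C(F)(F)F)n3)cc2C)on1`: 1.58 h
Compound 2 `CCOCc1cc(CCCOc2c(C)cc(-c3noc(C(F)(F)F)n3)cc2C)on1`: > 2.5 h (a limit)
Compound 3 `Cc1cc(CCCOc2c(C)cc(-c3noc(CF)n3)cc2C)on1`: 0.233 h

In an in vitro ADME assay on microsomes from liver (Simiiformes) (a lower number here means that the compound disappears faster, a higher number that the compound lasts longer), compound 3 holds the lowest number, 0.233 h. Compound 1 gives 1.58 h, a gap beyond the scatter. Compound 4 `COc1nc(-c2cc(C)c(OCCCc3cc(C)no3)c(C)c2)no1` carries methoxy in place of fluoromethyl on an aromatic carbon. Within the data shown here, the only measured step, an at least 1.5-fold higher number from compound 1 to compound 2 (0.19 log units; that floor lies within the scatter), concerns a different change at a different place, so it gives no size for this one. No step beyond the scatter is therefore expected, in either direction. The estimated step is a 1.5-fold higher number from compound 3 to compound 4 (0.18 log units; within the scatter). Compound 4 is expected at 0.35 h, with an estimated range of 0.12 h to 1 h.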

Compound 4, half-life: 0.55 h
Beside the measured number, compound 4's estimate is 1.6-fold (0.20 log units) below it; the range from low to high includes it.
By their numbers in this assay, from the lowest: compound 3; then compound 4; then compound 1. At a limit, above all of these: compound 2.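

The earlier compounds shown here gave no measured step at this aromatic carbon, next to the ring nitrogen and the ring oxygen. In this assay, methoxy in place of fluoromethyl gives a 2.4-fold higher number from compound 3 to compound 4 (0.37 log units; beyond the scatter), so an exchange of equal heavy-atom count, which adds one hydrogen-bond acceptor, already moves the half-life here beyond the scatter. Nothing shown accounts for the size of this step.

From the compounds shown here alone, whether an amine, a nitrile or a longer chain such as ethoxy at this carbon would give a longer half-life remains open. So does whether the step from fluoromethyl to methoxy keeps its size with the methoxymethyl group of compound 1 elsewhere on the core.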